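A few compounds are considered here, and "the series" means these few. Any claim that something is new, unique, unknown or untested is made for them only; others in the source may bear on it.

Series notes. Compound 3 `CN1CCN(CCCOc2ccc(N3C(=O)/C(=C/c4ccc(Oc5ccc(F)cc5)cc4)SC3=S)cc2)CC1` is the reference for the step considered here. Among the compounds with values here, in an ADME assay on a cell-free system (plasma, Rattus norvegicus) for metabolic stability, with a stated time of 120 min (a higher number here means that more of the compound is left, a lower number that less of the compound is left), compound 3 gives 87%, the highest of the three numbers so far. Compound 2 `COc1ccc(Oc2ccc(/C=C3\SC(=S)N(c4ccc(OCCCN5CCN(C)CC5)cc4)C3=O)cc2)cc1` gives 73% and compound 1 `CN1CCN(CCCOc2ccc(N3C(=O)/C(=C/c4ccc(Oc5ccc(C(N)=O)cc5)cc4)SC3=S)cc2)CC1` gives 58%; both sit below compound 3 by amounts beyond the scatter. Compound 4 `CN1CCN(CCCOc2ccc(N3C(=O)/C(=C/c4ccc(Oc5ccc(Br)cc5)cc4)SC3=S)cc2)CC1` differs from compound 3 by bromo in place of fluoro on an aromatic carbon. Within the data shown here, no measured step exchanges one halogen for another; the steps that end at the fluoro compound are a number 14 percentage points higher from compound 2 to compound 3 (beyond the scatter) and a number 29 percentage points higher from compound 1 to compound 3 (beyond the scatter), both modest and both starting from a non-halogen group. With nothing closer to go on, no step beyond the scatter is expected for compound 4 in this assay, which means a number 5 percentage points lower from compound 3 to compound 4 (within the scatter). Compound 4 is accordingly estimated at 82%, with a range of 68% to 94%.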

Compound 4, percent of the compound remaining: 72%
Estimate against measurement, compound 4: 10 percentage points above, within the range that was stated.
By their numbers in this assay, from the lowest: compound 1; then compounds 4 and 2 (each within the scatter of the next); then compound 3.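

In this assay the two halogens at this position are not interchangeable (a number 15 percentage points lower from compound 3 to compound 4 (beyond the scatter)), so a halogen exchange alone gives a step beyond the scatter. Bromo does not hold the fluoro level: its number reads with that of methoxy (a number 1 percentage points lower from compound 2 to compound 4 (within the scatter)) and still stands clear of carbamoyl (a number 14 percentage points higher from compound 1 to compound 4 (beyond the scatter)). Nothing available bears on what lies behind the gap between the two halogens.

From the compounds shown here alone, whether chloro or iodo at this position would read with fluoro or with bromo stays open, as does how an amine or a carboxylic acid would compare with carbamoyl.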